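Acyl variation on the shared core: cytotoxicity notes

The source may hold more compounds than are shown below. What is called first, only, known or untested is meant among the compounds shown, and "the series" means these compounds.

Measured so far:
- compound 1 `CCCC(=O)OCCc1c(-c2ccccc2Cl)c2cc(Cl)ccc2[nH]c1=O` gives 52000 nM in an ADME assay on HepG2 2.2.15 cells (Homo sapiens) for cytotoxicity; on this read-out higher numbers stand for lower toxicity in this test and lower numbers for higher toxicity in this test
- compound 2 `CC12CCC(C(=O)OCCc3c(-c4ccccc4Cl)c4cc(Cl)ccc4[nH]c3=O)(OC1=O)C2(C)C` gives > 1800000 nM in this assay, which is a limit of the assay and not a number

Compound 2 therefore stands only at a bound in this assay, (the limit of > 1800000 nM in this assay, at which 1 of the 2 values shown sits), and no number is known for it. The step of an at least 34-fold higher number from compound 1 to compound 2 (1.53 log units; beyond the scatter) shows that an exchange of the acyl group on the carbonyl carbon can move the read-out a long way.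

Compound 3 `O=C(/C=C/c1cccc(C(F)(F)F)c1)OCCc1c(-c2ccccc2Cl)c2cc(Cl)ccc2[nH]c1=O` is next to be measured in this assay. Its change from compound 2: a group of 12 heavy atoms (9 carbon, 3 fluorine; one six-membered aromatic ring of carbon only) in place of a group of 11 heavy atoms (9 carbon, 2 oxygen; one five-membered non-aromatic ring of carbon only, one five-membered non-aromatic ring with 1 hetero atom), on a carbonyl carbon. Going by the values given here, the only measured step that bears on this position is the large one from compound 1 to compound 2; no measured compound carries the 2-(3-(trifluoromethyl)phenyl)ethenyl group, so its own effect is unknown. Given that exchange of the acyl group already produced a large step, a sizeable downward step an at least 15-fold lower number from compound 2 to compound 3 (1.17 log units; beyond the scatter) toward the region of compound 1 is expected, with a real chance that compound 3 again only reaches a limit. Compound 3 is estimated at 120000 nM, expected between 20000 nM and 800000 nM.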

Compound 3, half-maximal cytotoxic concentration: > 1400000 nM
Compound 3: only a limit was reported (the forecaster's own chance of this, stated with the estimate: 25%); middle value at least 11-fold (1.06 log units) away from the limit.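

In this assay, 2-(3-(trifluoromethyl)phenyl)ethenyl in place of propyl on a carbonyl carbon gives an at least 26-fold higher number from compound 1 to compound 3 (1.43 log units; beyond the scatter), so a second acyl group, of a very different kind from that of compound 2, also moves the read-out far from compound 1. Compound 3 stands only at a limit of the assay, and no number is known for it: the limit of > 1400000 nM in this assay, at which 1 of the 3 values shown sits. Compound 2 and compound 3 both sit at limits, so the step between them cannot be read and no order between the two can be stated, but the large rise from the propyl group now appears with two groups that share no ring type and differ in hydrogen-bond acceptors.

The compounds shown do not separate the presence of a ring from the number of heavy atoms in the group, and the true values of compound 2 and compound 3 remain unknown. On these data alone, whether a longer carbon chain without a ring would stay near compound 1 or rise to the same region, and what an acyl group carrying an amine would give at this position, remains open.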